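Methylamino for ethyl on the aniline ring of compound 3

The source may report more compounds than this note shows. Statements on the series, on what has been measured and on what is new or still open speak of the compounds shown alone.

Compound 3 `CCc1ccc(Nc2nccc(-c3ccccn3)n2)cc1` gives 2100 nM in a functional assay for inhibition, with Homo sapiens as the target; on this read-out lower numbers stand for stronger inhibition and higher numbers for weaker inhibition; it stands level with compound 1 `CNc1ccc(Nc2nccc(-c3cccnc3)n2)cc1` at the digits shown, which gives 2100 nM, and together they hold the lowest of the three numbers. Compound 2 `CCc1ccc(Nc2nccc(-c3ccncc3)n2)cc1` gives 7700 nM. Within the data shown here, the only single-place step measured so far is a 3.7-fold lower number from compound 2 to compound 3 (0.56 log units; beyond the scatter), a change in the pyridyl group, not in the substituent on the aniline ring.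

Compound 4 `CNc1ccc(Nc2nccc(-c3ccccn3)n2)cc1` differs from compound 3 by methylamino in place of ethyl on an aromatic carbon. Among the measured compounds shown here, no measured pair isolates this swap. Compounds 1 and 3 carry methylamino and ethyl, but they also differ in the pyridyl attachment, so their equal numbers show only that the two substituents can coexist with the same potency level when the pyridyl group changes as well. Nothing in the series points to a shift beyond the scatter in this assay, so compound 4 is expected to give 1800 nM, with a range of 700 nM to 4500 nM. The step of a 1.2-fold lower number from compound 3 to compound 4 (0.07 log units; within the scatter) is thus estimated to stay within the scatter.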

Compound 4, half-maximal inhibitory concentration: 1400 nM
Estimate against measurement, compound 4: 1.3-fold (0.11 log units) above; low and high end bracket the measured number.
By their numbers in this assay, from the lowest: compounds 4, 1 and 3 (each within the scatter of the next); then compound 2.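

In this assay, among these compounds, with pyridin-2-yl held fixed, methylamino in place of ethyl on the aromatic carbon para to a large group gives a 1.5-fold lower number from compound 3 to compound 4 (0.18 log units; within the scatter) and so stays within the scatter, which isolates this swap for the first time. Among the compounds shown here, with methylamino held fixed, pyridin-2-yl in place of pyridin-3-yl gives a 1.5-fold lower number from compound 1 to compound 4 (0.18 log units; within the scatter) and also stays within the scatter, while the only step beyond the scatter remains a 3.7-fold lower number from compound 2 to compound 3 (0.56 log units; beyond the scatter) in the ethyl compounds. No supporting data bear on these results.

As far as these compounds go, it remains open whether dimethylamino, a carboxylic acid or a longer chain such as propyl at this position would stay within the scatter of compound 4. From the compounds shown here alone, it is also open whether methylamino paired with pyridin-4-yl would follow the step seen with ethyl.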